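This account rests on a few compounds, and the source may have more. Where it says the series, first, only, none or still open, it means among the compounds named here.

Working notes on the series. Among the compounds with values here, in a functional assay on MCF7 cells (Homo sapiens) for cytotoxicity, read by CellTiter-Glo, with a stated time of 5 days (a lower number here means a stronger inhibitor, a higher number a weaker inhibitor), compound 2 `O=C(O)/C=C/c1ccc(/C(=C(/CCCl)c2ccccc2)c2ccc3[nH]ncc3c2)cc1` gives 9 nM, the lowest of the two numbers so far; the nearest is compound 1 `C/C(=C(/c1ccc(/C=C/C(=O)O)cc1)c1ccc2[nH]ncc2c1)c1ccccc1`, which in this assay gives 40 nM, and the step of a 4.4-fold lower number from compound 1 to compound 2 (0.65 log units; beyond the scatter) is the only one measured. Compound 3 `O=C(O)/C=C/c1ccc(/C(=C(\c2ccccc2)C2CCC2)c2ccc3[nH]ncc3c2)cc1` differs from compound 2 by cyclobutyl in place of 2-chloroethyl on a double-bonded chain carbon bound to an aromatic carbon and a double-bonded chain carbon. That measured step concerns the same chain carbon but adds a group where hydrogen stood; it does not tell how one such group compares with another, so no step beyond the scatter is expected in this assay. Compound 3 is estimated at 15 nM (range 5 nM to 45 nM), a step of a 1.7-fold higher number from compound 2 to compound 3 (0.22 log units; within the scatter).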

Compound 3, half-maximal inhibitory concentration: 1.4 nM
Compound 3: the middle estimate sits 11-fold (1.03 log units) above what was measured; the measured number lies below the stated range.
By their numbers in this assay, from the lowest: compound 3; then compound 2; then compound 1.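

At this double-bonded chain carbon, exchanging one group for another now has a measured size: cyclobutyl in place of 2-chloroethyl gives a 6.4-fold lower number from compound 2 to compound 3 (0.81 log units; beyond the scatter) and cyclobutyl in place of methyl gives a 29-fold lower number from compound 1 to compound 3 (1.46 log units; beyond the scatter) in the same assay. The position therefore still separates groups at the low end of the series, with the cyclobutyl of compound 3 beyond the scatter of both open-chain groups. Nothing available explains this difference.

Open, as far as these compounds go, is whether cyclopentyl or an open butyl chain at this carbon would match cyclobutyl. Also open, from the compounds shown here alone, is whether the ring itself or only the size of the group counts.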